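The source may report more compounds than this note shows. Statements on the series, on what has been measured and on what is new or still open speak of the compounds shown alone.

The series shares one core and varies the aryl group on the carbon carrying a double bond to nitrogen. In a functional assay on PC-3 cells (Homo sapiens) for inhibition (a lower number here means a stronger inhibitor, a higher number a weaker inhibitor), compound 1 `Cc1c(C(=O)N/N=C\c2cccc(O)c2O)oc2cccc(O)c12` gives 12200 nM, compound 2 `COc1ccccc1/C=N\NC(=O)c1oc2cccc(O)c2c1C` gives 32700 nM, and compound 3 `Cc1c(C(=O)N/N=C\c2ccc(Br)cc2O)oc2cccc(O)c12` gives 2050 nM. Compound 3 therefore stands lowest of the three measured numbers, with a 6.0-fold lower number from compound 1 to compound 3 (0.77 log units; beyond the scatter) and a 16-fold lower number from compound 2 to compound 3 (1.20 log units; beyond the scatter), while a 2.7-fold higher number from compound 1 to compound 2 (0.43 log units; beyond the scatter) separates the other two. Compound 4 `Cc1c(C(=O)N/N=C\c2cc(Cl)ccc2O)oc2cccc(O)c12` differs from compound 3 by 5-chloro-2-hydroxyphenyl in place of 4-bromo-2-hydroxyphenyl on a carbon with a double bond to nitrogen. The measured steps that bear on this change are the two that bring the 4-bromo-2-hydroxyphenyl group in, a 6.0-fold lower number from compound 1 to compound 3 (0.77 log units; beyond the scatter) and a 16-fold lower number from compound 2 to compound 3 (1.20 log units; beyond the scatter), one modest and one large. For the measured compounds named here, neither of them exchanges one halogen for another, and no pair among compounds 1 to 3 compares two halogenated hydroxyphenyl groups, so the data give no direct guide to the new step. Since both the leaving and the entering group carry a hydroxyl and a halogen, compound 4 is expected to stay close to compound 3, with at most a small rise in the number in this assay, as a 1.5-fold higher number from compound 3 to compound 4 (0.17 log units; within the scatter). On that basis compound 4 is estimated at 3000 nM in this assay, within a range from 1000 nM to 9000 nM.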

Compound 4, half-maximal inhibitory concentration: 3120 nM
For compound 4 the middle estimate is 1.0-fold (0.02 log units) below the measured one, within the range that was stated.
By their numbers in this assay, from the lowest: compounds 3 and 4 (each within the scatter of the next); then compound 1; then compound 2.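

In this assay, the exchange of 4-bromo-2-hydroxyphenyl for 5-chloro-2-hydroxyphenyl on the carbon with a double bond to nitrogen leaves the number unresolved (a 1.5-fold higher number from compound 3 to compound 4 (0.18 log units; within the scatter)), so this position tolerates a change of both the halogen and the place it holds on the hydroxyphenyl group without a difference that can be read. The gain seen with the bromine group is also not unique to it, since the chlorine group too stands apart from the 2-methoxyphenyl group (a 10-fold lower number from compound 2 to compound 4 (1.02 log units; beyond the scatter)) and from the 2,3-dihydroxyphenyl group (a 3.9-fold lower number from compound 1 to compound 4 (0.59 log units; beyond the scatter)). Among these four compounds, then, both halogen-bearing hydroxyphenyl groups give lower numbers than the two groups without a halogen, and none of the four goes against this.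

Nothing available explains these differences. From the compounds shown here alone, because halogen and place change together in this one step, it remains open how each acts alone, which a 5-bromo-2-hydroxyphenyl or a 4-chloro-2-hydroxyphenyl group would separate, and how an aminophenyl or carboxyphenyl group would fare here.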